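Phenol in place of tolyl: expected tolerance of compound 4

This account rests on a few compounds, and the source may have more. Where it says the series, first, only, none or still open, it means among the compounds named here.

Compound 1, `Cc1nc(-c2cccnc2)sc1-c1nnc(-c2ccccc2Cl)o1`: in an ADME assay on THP-1 cells (Homo sapiens) for cytotoxicity, read by MTT assay (a lower number here means that less compound is tolerated, a higher number that more compound is tolerated), compound 1 gives > 100 ug/mL, a limit of the assay.
Compound 2, `Cc1nc(-c2cccnc2)sc1-c1nnc(-c2cccc(Cl)c2Cl)o1`: in this assay compound 2 gives > 100 ug/mL, again a limit.
Compound 3, `Cc1ccccc1-c1nnc(-c2sc(-c3cccnc3)nc2C)o1`: in this assay compound 3 gives > 100 ug/mL, also a limit.

Compound 3 therefore stands where every measured compound stands, at the limit of > 100 ug/mL in this assay, at which 3 of the 3 values shown sit, and no number separates it from the others. The change to the unmeasured compound 4, `Cc1nc(-c2cccnc2)sc1-c1nnc(-c2ccc(O)cc2)o1`, is 4-hydroxyphenyl in place of 2-methylphenyl on an aromatic carbon. Among the measured compounds shown here, the steps that bear on this change are a step that the two limits leave unreadable from compound 1 to compound 2, a step that the two limits leave unreadable from compound 1 to compound 3 and a step that the two limits leave unreadable from compound 2 to compound 3, none of which can be read in size, since each ends at a limit on both sides. For the measured compounds named here, the data thus give no measured step on this core that moves the read-out beyond the scatter. The expected step of a number no higher from compound 3 to compound 4 (the limit leaves the size open) in this assay is accordingly none beyond the scatter. Compound 4 is expected to sit at 100 ug/mL, with a range from 50 ug/mL to 200 ug/mL, most likely reported once more as a limit.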

Compound 4, half-maximal cytotoxic concentration: > 100 ug/mL
Compound 4 gave a limit, no number (the forecaster's own chance of this, stated with the estimate: 80%); the middle value sits exactly at the limit.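

No step from compound 4 to compound 1, compound 2 or compound 3 can be read, since all four compounds end at the same limit: the limit of > 100 ug/mL in this assay, at which 4 of the 4 values shown sit.

The compounds shown leave open how much of any of them is tolerated in this assay, and whether 2-methylphenyl and 4-hydroxyphenyl on the shared core differ at all.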